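The compounds below may be only part of what the source reports. "The series", "measured", "known", "first", "only" and "open" are said of these compounds alone.

Measured compounds:
compound 1 `CC1=CC[C@H](C(C)(C)N=C=S)CC1` — in a functional assay on OVCAR-3 cells (Homo sapiens) for inhibition, read by sulforhodamine B assay, with a stated time of 48 h (on this read-out higher numbers stand for weaker inhibition of growth and lower numbers for stronger inhibition of growth), compound 1 reads > 100000 nM, which is a limit of the assay and not a number.
compound 2 `COc1ccc(/C=N/NC(=S)NC(C)(C)[C@H]2CC=C(C)CC2)cc1` — in this assay compound 2 gives 7900 nM.

Within the data shown here, compound 2 therefore holds the only number in this assay; compound 1 sits at the limit of > 100000 nM in this assay, at which 1 of the 2 values shown sits. Among the measured compounds shown here, no step between two measured compounds is available, so the series gives no calibration for the change in hand.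

Compound 3 `CC1=CC[C@H](C(C)(C)NC(=S)N/N=C/c2ccc(F)cc2)CC1` differs from compound 2 by fluoro in place of methoxy on an aromatic carbon. For the measured compounds named here, with no measured step of comparable kind, the expectation is a small step in this assay, not clearly beyond the usual scatter, with a slight lean towards weaker growth inhibition. On that basis compound 3 is expected at 11000 nM, within a range of 4000 nM to 35000 nM. The step this estimate implies is a 1.4-fold higher number from compound 2 to compound 3 (0.14 log units; within the scatter); a measured value for compound 3 will show whether the estimate holds.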

Compound 3, concentration for 50% growth inhibition: > 100000 nM
Compound 3: a limit, no number; the forecaster's own chance of this, stated with the estimate: 10%; middle value at least 9.0-fold (0.95 log units) away from the limit.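

In this assay the change from 4-methoxyphenyl to 4-fluorophenyl, on an aromatic carbon para to a large group, gives an at least 12-fold higher number from compound 2 to compound 3 (1.10 log units; beyond the scatter) and so is not a neutral swap at this place. Compound 3 carries a limit and not a number, so the step can be read only as a lower bound on its size. Of the compounds shown, compound 2 alone gives a number, and the 4-fluorophenyl compound joins compound 1 at the limit: the limit of > 100000 nM in this assay, at which 2 of the 3 values shown sit.

The compounds shown do not separate the effect of losing methoxy from that of gaining fluoro, as an unsubstituted phenyl would. Going by these compounds, whether an ethoxy, a hydroxy or a dimethylamino group at this place keeps a measurable number also stays open.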